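The compounds below may be only part of what the source reports. "The series", "measured", "known", "first", "only" and "open" are said of these compounds alone.

Measured in an ADME assay on BJ cells (Homo sapiens) for cytotoxicity, with a stated time of 72 h; on this read-out higher numbers stand for an effect only at larger amounts of compound and lower numbers for an effect already at smaller amounts:
compound 1 `O=C(Nc1ccc(O)c(-c2nc3ccccc3s2)c1)c1cc([N+](=O)[O-])ccc1Cl`: > 25000 nM (a limit)
compound 2 `O=C(Nc1ccc(Cl)c(-c2nc3ccccc3s2)c1)c1cc([N+](=O)[O-])ccc1Cl`: > 25000 nM (a limit)

Compound 2 offers no number, only (the limit of > 25000 nM in this assay, at which 2 of the 2 values shown sit). Compound 3 `O=C(Nc1ccc(Cl)c(C(F)(F)F)c1)c1cc([N+](=O)[O-])ccc1Cl` differs from compound 2 as follows: trifluoromethyl in place of 1,3-benzothiazol-2-yl on an aromatic carbon. This puts trifluoromethyl in place of 1,3-benzothiazol-2-yl on an aromatic carbon, ortho to a chloro group. Among the measured compounds shown here, the one measured step, a step that the two limits leave unreadable from compound 1 to compound 2, gives no size to carry over. In this assay no change beyond the scatter is therefore expected, and no direction can be read. The expected step is a number no higher from compound 2 to compound 3 (the limit leaves the size open). Compound 3 is estimated at 25000 nM, with an expected range of 10000 nM to 50000 nM.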

Compound 3, half-maximal effective concentration: > 27000 nM
Compound 3: a limit, no number (the forecaster's own chance of this, stated with the estimate: 75%); middle value at least 1.0-fold (0.03 log units) away from the limit.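

Among the compounds shown here, compound 2 and compound 3 both give only limits in this assay; no step between them can be read. The compounds shown leave open at what concentration any of them would reach a half-maximal effect on these cells.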